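Cyclopropyl for phenyl on the ring amide nitrogen

A few compounds are considered here, and "the series" means these few. Any claim that something is new, unique, unknown or untested is made for them only; others in the source may bear on it.

Within the data shown here, in a functional assay on A-375 cells (Homo sapiens) for antiproliferative activity, read by MTT assay, with a stated time of 72 h (a lower number here means a stronger inhibitor, a higher number a weaker inhibitor), compound 1 (`CC(C)N1C(=O)COc2ccc(-c3cnc(Cl)c(NS(=O)(=O)c4ccc(F)cc4)c3)cc21`) gives 25500 nM and compound 2 (`O=C1COc2ccc(-c3cnc(Cl)c(NS(=O)(=O)c4ccc(F)cc4)c3)cc2N1c1ccccc1`) gives 36900 nM so compound 2 stands level with its only measured neighbour, the two values lying within the scatter of each other. Compound 3 (`O=C1COc2ccc(-c3cnc(Cl)c(NS(=O)(=O)c4ccc(F)cc4)c3)cc2N1C1CC1`) carries cyclopropyl in place of phenyl on an amide-type nitrogen in a ring and otherwise keeps the structure of compound 2. Among the measured compounds shown here, the one measured step at this nitrogen is a 1.4-fold higher number from compound 1 to compound 2 (0.16 log units; within the scatter) with phenyl in place of isopropyl, and it stays within the scatter. For the measured compounds named here, no measurement yet covers cyclopropyl on this nitrogen, so the expectation rests on that single small step alone. No step beyond the scatter is therefore expected in this assay in either direction, and the series would stay in the same range of values. Compound 3 is expected at 28000 nM with an estimated range from 13000 nM to 55000 nM in this read-out. The estimated change is a 1.3-fold lower number from compound 2 to compound 3 (0.12 log units; within the scatter) and would lie within the scatter.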

Compound 3, half-maximal inhibitory concentration: 21800 nM
Estimate against measurement, compound 3: 1.3-fold (0.11 log units) above; the range from low to high includes it.
By their numbers in this assay, from the lowest: compounds 3, 1 and 2 (each within the scatter of the next).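

In this assay, replacing phenyl with cyclopropyl on the amide-type nitrogen in a ring gives a 1.7-fold lower number from compound 2 to compound 3 (0.23 log units; within the scatter), and replacing isopropyl with cyclopropyl at the same nitrogen gives a 1.2-fold lower number from compound 1 to compound 3 (0.07 log units; within the scatter), so compounds 1, 2 and 3 now all lie within the scatter of one another. The exchange of a six-membered aromatic ring of 6 heavy atoms for a three-membered non-aromatic ring of 3 heavy atoms therefore leaves the number in the same range, and among these three compounds no group at this nitrogen stands apart. No supporting data bear on why the values at this position stay together.

As far as these compounds go, compounds 1, 2 and 3 cover only isopropyl, phenyl and cyclopropyl on this nitrogen, all groups of carbon and hydrogen alone, so it remains open whether a longer chain ending in an amine or a carboxylic acid would produce a step beyond the scatter. From the compounds shown here alone, it also remains open whether this flat response holds when other parts of the shared core change, since all three compounds keep the rest of the structure unchanged.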